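Ortho substituent on the phenyl ester and Vero cytotoxicity

This account rests on a few compounds, and the source may have more. Where it says the series, first, only, none or still open, it means among the compounds named here.

Measured so far:
compound 1 `O=C(CC1SC(=O)NC1=O)Oc1ccc(/C=N/NC(=O)c2ccncc2)cc1Cl`, 31.9 ug/mL
compound 2 `O=C(CC1SC(=O)NC1=O)Oc1ccc(/C=N/NC(=O)c2ccncc2)cc1Br`, 190 ug/mL
compound 3 `O=C(CC1SC(=O)NC1=O)Oc1ccc(/C=N/NC(=O)c2ccncc2)cc1`, 91.7 ug/mL

All three share one core and differ only at one aromatic carbon, measured in an ADME assay on Vero cells (Chlorocebus sabaeus) for cytotoxicity, read by MTT assay, with a stated time of 24 h; a higher number here means a weaker inhibitor, a lower number a stronger inhibitor. Compound 3, the unsubstituted parent, sits second highest of the three numbers, with compound 2 nearest and compound 1 furthest.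

Compound 4 `COc1cc(/C=N/NC(=O)c2ccncc2)ccc1OC(=O)CC1SC(=O)NC1=O` carries the change (methoxy in place of hydrogen on an aromatic carbon), at the same aromatic carbon that holds the halogens in compounds 1 and 2. Going by the values given here, the steps that bear on it point in opposite directions: a 2.9-fold higher number from compound 1 to compound 3 (0.46 log units; beyond the scatter), whereas a 2.1-fold lower number from compound 2 to compound 3 (0.32 log units; beyond the scatter). A substituent here thus moves the number modestly either way, with no consistent direction. For compound 4 a modest step is expected, direction uncertain, a 1.1-fold higher number from compound 3 to compound 4 (0.04 log units; within the scatter). Compound 4 is estimated at 100 ug/mL, within 35 ug/mL to 280 ug/mL.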

Compound 4, half-maximal inhibitory concentration: 203 ug/mL
Compound 4: the middle estimate sits 2.0-fold (0.31 log units) below what was measured; measured number inside the range.
By their numbers in this assay, from the lowest: compound 1; then compound 3; then compounds 2 and 4 (each within the scatter of the next).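

In this assay, methoxy moves the number up from the unsubstituted parent (a 2.2-fold higher number from compound 3 to compound 4 (0.35 log units; beyond the scatter)), so methoxy and bromo both raise it at this aromatic carbon, while chloro in compound 1 goes against them. Methoxy and bromo cannot be told apart here (a 1.1-fold higher number from compound 2 to compound 4 (0.03 log units; within the scatter)), whereas methoxy stands clearly apart from chloro (a 6.4-fold higher number from compound 1 to compound 4 (0.80 log units; beyond the scatter)). Nothing on hand explains why chloro differs from the other two substituents.

As far as these compounds go, whether an amine, a carboxylic acid or a longer chain such as ethoxy at this carbon would follow chloro or methoxy remains open.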